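The compounds below may be only part of what the source reports. "The series", "measured", "known", "first", "only" and "open" are said of these compounds alone.

Measured compounds:
Compound 1 `COC(=O)C1=C(C)NC(C)=C(C(=O)OC)C1c1cnc(SC)n1Nc1ccccc1`: 3.54 nM
Compound 2 `CCOC(=O)C1=C(C)NC(C)=C(C(=O)OCC)C1c1cnc(SC)n1Nc1ccccc1`: 1.69 nM
Compound 3 `CSc1ncc(C2C(C(=O)OCCCc3ccccc3)=C(C)NC(C)=C2C(=O)OCCCc2ccccc2)n1Nc1ccccc1`: 3.15 nM

All three were tested in an assay on isolated protein (strain albino) for antagonist activity at Voltage-dependent L-type calcium channel subunit alpha-1C (Cavia porcellus); a lower number here means a stronger inhibitor, a higher number a weaker inhibitor. Compound 2 has the lowest number of the three. Its gap to compound 3 lies within the usual scatter of repeated measurements, so the two cannot be told apart; only compound 1 stands beyond the scatter from compound 2, with a somewhat higher number.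

Compound 4 `CCOC(=O)C1=C(C)NC(C)=C(C(=O)OC)C1c1cnc(SC)n1Nc1ccccc1` has not yet been measured in this assay. It differs from compound 2 in one place: hydrogen in place of methyl on a saturated chain carbon bound to an oxygen next to a carbonyl group. One of the two ester groups thus becomes the same as in compound 1, while the other stays as in compound 2. Since both ends of this change are already covered, the expected step from compound 2 to compound 4 is small and probably none beyond the scatter, leaning at most slightly toward a higher number, a 1.4-fold higher number from compound 2 to compound 4 (0.15 log units; within the scatter). For compound 4 the estimate in this assay is 2.4 nM, with a range from 1.2 nM to 5 nM, because compound 1 gives 3.54 nM and compound 2 gives 1.69 nM and compound 4 lies between them in structure.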

Compound 4, half-maximal inhibitory concentration: 1.66 nM
The estimate for compound 4 lay 1.4-fold (0.16 log units) above the measured number; measured number inside the range.
By their numbers in this assay, from the lowest: compounds 4, 2, 3 and 1 (each within the scatter of the next, the first and the last beyond it).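

In this assay, turning one ethoxycarbonyl group of compound 2 into methoxycarbonyl gives a 1.0-fold lower number from compound 2 to compound 4 (0.01 log units; within the scatter), so this ester can lose its methyl without any visible effect as long as the other ester remains ethyl. Read from the other side, the methyl added to one ester of compound 1 gives a 2.1-fold lower number from compound 1 to compound 4 (0.33 log units; beyond the scatter), a modest step beyond the scatter. One ethyl ester therefore accounts for the whole gap between the dimethyl and diethyl esters, and the second ethyl adds nothing that can be seen; no evidence shown explains this.

Still open, from the compounds shown here alone, is whether a carboxylic acid or an amide in place of this ester would keep the number as low. Going by these compounds, a branched chain such as isopropyl also remains untested against ethyl here.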